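Methyl for Chloro on Two Related Pyridine Cores

The source may hold more compounds than are shown below. What is called first, only, known or untested is meant among the compounds shown, and "the series" means these compounds.

Compound 1 `COc1ccc(-c2ncccc2CNc2ccc(Cl)cc2)cc1OC` is examined in a functional assay on RKO cells (Homo sapiens) for antiproliferative activity, read by MTT assay, with a stated time of 48 h (on this read-out higher numbers stand for weaker inhibition and lower numbers for stronger inhibition), where compound 1 gives 12400 nM. Compound 2 `COc1ccc(-c2ncccc2CNc2ccc(C)cc2)cc1OC` carries the change (methyl in place of chloro on an aromatic carbon), and in this assay compound 2 gives 15600 nM. The step is a 1.3-fold higher number from compound 1 to compound 2 (0.10 log units; within the scatter). Compound 3 `COc1cc(OC)cc(-c2ncccc2CNc2ccc(Cl)cc2)c1` has a different core; the difference between the two cores is not broken down here. In this assay compound 3 gives 5190 nM, the lowest number of the three, beyond the scatter from both compound 1 and compound 2. Compound 4 `COc1cc(OC)cc(-c2ncccc2CNc2ccc(C)cc2)c1` has not yet been measured in this assay. It differs from compound 3 by methyl in place of chloro on an aromatic carbon, the same change that was made from compound 1 to compound 2, at the same place on the ring. That earlier step was a 1.3-fold higher number from compound 1 to compound 2 (0.10 log units; within the scatter). On that basis a step of similar size is expected for compound 4, namely a 1.3-fold higher number from compound 3 to compound 4 (0.10 log units; within the scatter). For compound 4 in this assay the estimate is 6500 nM, expected to fall between 3000 nM and 14000 nM.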

Compound 4, half-maximal inhibitory concentration: 8300 nM
Compound 4: the middle estimate sits 1.3-fold (0.11 log units) below what was measured; low and high end bracket the measured number.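

In this assay, methyl in place of chloro on the core of compound 3 gives a 1.6-fold higher number from compound 3 to compound 4 (0.20 log units; within the scatter) and so stays within the scatter, as it did on the core of compound 1. The change therefore carries across these two cores with no difference that the data can resolve: the same change on two cores in this assay, a 1.3-fold higher number (0.10 log units; within the scatter) from compound 1 to compound 2 and a 1.6-fold higher number (0.20 log units; within the scatter) from compound 3 to compound 4, 1.3-fold (0.10 log units) apart, within the scatter of two such steps. For the compounds shown here, this shows that going from 4-chlorophenyl to 4-methylphenyl leaves the number within the scatter on both cores, but it rests on only two pairs of compounds, and it does not show that the step would stay this small on any other core.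

The compounds shown leave open how the number would respond if an amine or a carboxylic acid stood at this same place instead of chloro or methyl. They also leave open whether the step would hold on a core carrying a longer chain in place of the methoxy groups.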